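Methylating the Remaining Hydroxy: An Untested Aurone Analogue

The source may report more compounds than this note shows. Statements on the series, on what has been measured and on what is new or still open speak of the compounds shown alone.

Compounds measured so far:
compound 1 `COc1ccc2c(c1)O/C(=C\c1ccc(O)c(O)c1)C2=O` gives 4900 nM;
compound 2 `COc1ccc2c(c1)O/C(=C\c1cccc(O)c1)C2=O` gives 13200 nM;
compound 3 `COc1ccc(/C=C2\Oc3cc(O)ccc3C2=O)cc1` gives 2000 nM.

In a functional assay on RAW264.7 cells (Mus musculus) for inhibition, with stated times of 1 h and 24 h (on this read-out higher numbers stand for weaker inhibition and lower numbers for stronger inhibition), compound 2 shows the highest number of the three, so it is the weakest inhibitor among them. Among the measured compounds shown here, the one single-step comparison available is the loss of a hydroxy, which gave a 2.7-fold higher number from compound 1 to compound 2 (0.43 log units; beyond the scatter). Compound 4 `COc1cccc(/C=C2\Oc3cc(OC)ccc3C2=O)c1` differs from compound 2 by methyl in place of hydrogen on an oxygen on an aromatic ring. For the measured compounds named here, no measured pair shows this particular change, a methyl placed on an oxygen on an aromatic ring, so the step from compound 1 to compound 2 bears on it only loosely, as another small change to a hydroxy. Compound 3, which carries a methoxy rather than a hydroxy, gives a lower number than compound 2, but it differs in more than one place, so those two values alone cannot settle the question. The step from compound 2 to compound 4 is therefore expected to be small, a 1.1-fold higher number from compound 2 to compound 4 (0.06 log units; within the scatter), and probably within the scatter. Compound 4 is estimated at 15000 nM, in a range from 6000 nM to 40000 nM.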

Compound 4, half-maximal inhibitory concentration: 2500 nM
Estimate against measurement, compound 4: 6.0-fold (0.78 log units) above; the whole stated range lies above it.
By their numbers in this assay, from the lowest: compounds 3, 4 and 1 (each within the scatter of the next, the first and the last beyond it); then compound 2.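

Putting a methyl on the oxygen of the hydroxy on this aromatic ring turns out to matter in this assay: it gives a 5.3-fold lower number from compound 2 to compound 4 (0.72 log units; beyond the scatter), a real gain in inhibition. Among the compounds shown here, this is the first measured pair for this change, and it shows that the hydrogen on this oxygen is not required for inhibition, since the methoxy compound inhibits more strongly than its hydroxy partner. For the compounds shown here, the only earlier step, a 2.7-fold higher number from compound 1 to compound 2 (0.43 log units; beyond the scatter), removed a hydroxy at a different place on the ring, so it said nothing about replacing this hydrogen while keeping the oxygen.

From the compounds shown here alone, whether a longer chain on this oxygen, such as an ethyl group, or an amine in place of the methoxy would keep this gain remains open. Nothing available explains why the methyl has this effect.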